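Oxazole ketone series: aryl-to-ester-chain swap at compound 4

A few compounds are considered here, and "the series" means these few. Any claim that something is new, unique, unknown or untested is made for them only; others in the source may bear on it.

Three ketones sharing one core have numbers in an assay for inhibition of Fatty-acid amide hydrolase 1 (Rattus norvegicus), using a Dixon plot; a lower number here means a stronger inhibitor, a higher number a weaker inhibitor. Compound 1 `COCOCc1ccc(-c2cnc(C(=O)CCCCCCc3ccccc3)o2)nc1` gives 10.1 nM; compound 2 `O=C(CCCCCCc1ccccc1)c1ncc(-c2ccc(CO)cn2)o1` gives 3.2 nM; compound 3 `C[S+]([O-])/C=C/c1ccc(-c2cnc(C(=O)CCCCCCc3ccccc3)o2)nc1` gives 3 nM. Compound 2 stands second highest of the three, with compound 3 nearest and compound 1 furthest; the step of a 3.2-fold lower number from compound 1 to compound 2 (0.50 log units; beyond the scatter) lies beyond the scatter, while a 1.1-fold lower number from compound 2 to compound 3 (0.03 log units; within the scatter) does not. The step of a 3.4-fold lower number from compound 1 to compound 3 (0.53 log units; beyond the scatter) is of the same modest size as the first.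

Compound 4 `COC(=O)CCCCc1cnc(C(=O)CCCCCCc2ccccc2)o1` is not yet measured. It differs from compound 2 by 4-(methoxycarbonyl)butyl in place of 5-(hydroxymethyl)pyridin-2-yl on an aromatic carbon. None of the three measured steps changes this part of the molecule: each of them alters only the group carried on the 5-(hydroxymethyl)pyridin-2-yl, and those alterations gave at most modest steps. Among the measured compounds shown here, no measured pair therefore speaks directly to removing that ring in favour of a 4-(methoxycarbonyl)butyl chain, and the expectation must be wide. A weaker number is expected for compound 4, with a 13-fold higher number from compound 2 to compound 4 (1.10 log units; beyond the scatter) as the estimated step. Compound 4 is estimated at 40 nM, within 6 nM to 300 nM.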

Compound 4, inhibition constant: 1.8 nM
For compound 4 the middle estimate is 22-fold (1.35 log units) above the measured one; the whole stated range lies above it.
By their numbers in this assay, from the lowest: compounds 4, 3 and 2 (each within the scatter of the next); then compound 1.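

In this assay, the swap at this position, on the aromatic carbon next to the ring oxygen, gives a 1.8-fold lower number from compound 2 to compound 4 (0.25 log units; within the scatter). The earlier steps shown here altered only the group carried on the 5-(hydroxymethyl)pyridin-2-yl, whereas this one replaces the whole group with a chain of no ring, showing that neither the six-membered aromatic ring nor the hydrogen-bond donor of the leaving group is needed to hold the number in this assay. No measured information bears on why these two different groups read alike.

The compounds shown leave open whether the methoxycarbonyl end of the chain matters, which a carboxylic acid or a plain alkyl end at this place would test. They also leave open how the number depends on chain length, which a longer chain carrying the same ester would address.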